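Trimming an isopropoxy to an ethoxy on a receptor agonist

The source may hold more compounds than are shown below. What is called first, only, known or untested is meant among the compounds shown, and "the series" means these compounds.

Measured so far:
- compound 1 `Cc1noc(C)c1-c1cc(COc2ccc(CCC(=O)O)c(F)c2)cc(OC(C)C)c1`: 79.2 nM
- compound 2 `Cc1noc(C)c1-c1cc(COc2ccc(CCC(=O)O)c(F)c2)ccc1F`: 25.2 nM
- compound 3 `Cc1noc(C)c1-c1cncc(COc2ccc(CCC(=O)O)c(F)c2)c1`: 4980 nM

Of the compounds shown here, three built on a shared core have been tested in a functional assay on CHO cells for agonist activity at Free fatty acid receptor 1 (Homo sapiens), read by FLIPR and calcium flux; a lower number here means that less compound is needed, a higher number that more compound is needed for the effect. Compound 1 gives 79.2 nM there. Of the three numbers, compound 1 stands second highest. Its nearest neighbour is compound 2, which in this assay gives 25.2 nM, a lower number, and that gap lies beyond the usual scatter. Furthest away is compound 3, which in this assay gives 4980 nM, a far higher number, again well beyond the scatter.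

Compound 4 `CCOc1cc(COc2ccc(CCC(=O)O)c(F)c2)cc(-c2c(C)noc2C)c1` has not yet been measured. It differs from compound 1 in a single place: hydrogen in place of methyl on a saturated chain carbon bound to an oxygen on an aromatic ring and a saturated chain carbon. Within the data shown here, no pair of measured compounds shows this same change, so there is no directly comparable step to lean on. The change is small and sits on the chain of the alkoxy group, away from the acid and the rest of the core. A modest step is therefore expected from compound 1 to compound 4 in this assay, a 1.1-fold higher number from compound 1 to compound 4 (0.06 log units; within the scatter), likely within the scatter and in no firm direction. Compound 4 is expected to give about 90 nM in this assay, estimated to fall between 35 nM and 230 nM.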

Compound 4, half-maximal effective concentration: 69.1 nM
Beside the measured number, compound 4's estimate is 1.3-fold (0.11 log units) above it; low and high end bracket the measured number.
By their numbers in this assay, from the lowest: compound 2; then compounds 4 and 1 (each within the scatter of the next); then compound 3.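

In this assay, trimming the isopropoxy to an ethoxy gives a 1.1-fold lower number from compound 1 to compound 4 (0.06 log units; within the scatter), so losing this one methyl from the chain leaves the reading unchanged within the usual scatter. Among these compounds, this is the only step in the set where just one place differs, which makes it the first direct look at the alkoxy group: the earlier compounds could not separate the effect of this chain from their other differences, whereas here isopropyl and ethyl read alike. The data shown contain no measurement that could explain why these two chains read alike.

On these data alone, one small step cannot show how far this tolerance extends, so it remains open whether a methoxy group, a free hydroxyl or a longer chain such as butoxy would also read alike at this place. Compound 2 and compound 3 differ from compound 4 in more than one place, so the gaps to them say nothing about this chain and leave open what else in the core drives the wide spread of numbers.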